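The source may hold more compounds than are shown below. What is called first, only, known or untested is meant among the compounds shown, and "the series" means these compounds.

Compound 1 `Cc1ccccc1-c1nc(CN2CCC(C(=O)NCCCN3CCC(C)(C)CC3)CC2)c(C)o1` gives 241 10^-6 cm/s in a physicochemical assay for permeability, using PAMPA (a lower number here means that the compound crosses the layer more slowly, a higher number that the compound crosses the layer faster), and is the only compound with a number shown in this assay. Compound 2 `Cc1oc(-c2c(Br)cccc2Br)nc1CN1CCC(C(=O)NCCCN2C[C@H](C)C[C@H](C)C2)CC1` is recorded in this assay only as a limit, < 1 10^-6 cm/s, which is the limit of < 1 10^-6 cm/s in this assay, at which 1 of the 2 values shown sits. Compound 3 `CCCN(CCC)CCNC(=O)C1CCN(Cc2nc(-c3ccccc3C)oc2C)CC1` differs from compound 1 by dipropylamino in place of (4,4-dimethylpiperidin-1-yl)methyl on a saturated chain carbon, two bonds along the chain from an amide-type nitrogen. For the measured compounds named here, no measured pair shows this change, so no step for it is known. The step of a 1.2-fold lower number from compound 1 to compound 3 (0.08 log units; within the scatter) is expected to stay within the usual scatter, without a clear direction. Compound 3 is therefore estimated at 200 10^-6 cm/s in this assay, with a range from 80 10^-6 cm/s to 400 10^-6 cm/s.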

Compound 3, apparent permeability: 913 10^-6 cm/s
For compound 3 the middle estimate is 4.6-fold (0.66 log units) below the measured one; measured number outside the range, above it.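

In this assay, the position on a saturated chain carbon, two bonds along the chain from an amide-type nitrogen, responds to this change: dipropylamino in place of (4,4-dimethylpiperidin-1-yl)methyl gives a 3.8-fold higher number from compound 1 to compound 3 (0.58 log units; beyond the scatter). For the compounds shown here, the earlier compounds held no pair differing in one place, so this is the first step that can be read, and it rests on a single pair. Nothing measured here accounts for the step.

The change from 3-(4,4-dimethylpiperidin-1-yl)propyl to 2-(dipropylamino)ethyl alters ring and chain together, and the compounds shown leave open which of the two carries the step. Also open, from the compounds shown here alone, is how a diethylamino group or a morpholine on the same chain would read in this assay.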